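This account rests on a few compounds, and the source may have more. Where it says the series, first, only, none or still open, it means among the compounds named here.

Working notes on the series. For the measured compounds named here, compound 3 `COc1cc(-c2nnc(SCC(=O)Nc3ccccc3)n2N)cc(OC)c1OC` is the only member with a number in a functional assay on HepG2 cells (Homo sapiens) for antiproliferative activity, read by MTT assay, with a stated time of 48 h; a higher number here means a weaker inhibitor, a lower number a stronger inhibitor; compound 3 gives 49900 nM. Compound 1 `COc1cc(-c2nnc(SCC(=O)c3ccc(C(F)(F)F)cc3)n2N)cc(OC)c1OC` reaches only a limit of the assay, > 100000 nM. Compound 2 `COc1cc(-c2nnc(SCC(=O)c3ccc(F)c(F)c3)n2N)cc(OC)c1OC` likewise reaches only a limit, > 100000 nM. The step that the two limits leave unreadable from compound 1 to compound 2 cannot be read because the limit of > 100000 nM in this assay, at which 2 of the 3 values shown sit, catches both ends. The steps of an at least 2.0-fold lower number from compound 1 to compound 3 (0.30 log units; that floor lies within the scatter) and an at least 2.0-fold lower number from compound 2 to compound 3 (0.30 log units; that floor lies within the scatter) run from a limit to a number, so each is a floor only, and that floor lies within the scatter. All three measured steps swap the whole group on the carbonyl carbon; none of them touches the anilino ring itself once it is in place.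

Compound 4 `COc1cc(-c2nnc(SCC(=O)Nc3ccccc3C)n2N)cc(OC)c1OC` differs from compound 3 by methyl in place of hydrogen on an aromatic carbon. Going by the values given here, no measured step bears on a methyl entering on an aromatic carbon of the anilino ring, so there is nothing to read a direction from. The expectation in this assay is therefore a step of no size beyond the scatter, a 1.0-fold higher number from compound 3 to compound 4 (0.00 log units; within the scatter), anchored on compound 3 at 49900 nM. Compound 4 is accordingly estimated at 50000 nM, with a range from 20000 nM to 150000 nM.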

Compound 4, half-maximal inhibitory concentration: > 100000 nM
Compound 4 was reported as a limit (the forecaster's own chance of this, stated with the estimate: 30%); middle value at least 2.0-fold (0.30 log units) away from the limit.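

For the compounds shown here, the methyl, ortho to a large group on the anilino ring, gives the first step on that ring itself in this assay: an at least 2.0-fold higher number from compound 3 to compound 4 (0.30 log units; that floor lies within the scatter). This is a floor and not a size, and as that floor lies within the scatter, the result does not establish that this position tolerates the methyl poorly, though it does take the series' only numbered compound back to the limit of the assay. The steps to compound 4 from the two carbonyl-linked aryl compounds, compound 1 and compound 2, cannot be read because both ends of each are limits: the limit of > 100000 nM in this assay, at which 3 of the 4 values shown sit.

Going by these compounds alone, compound 3 therefore remains the only anchor with a number, and how far compound 4 lies from it stays unknown. Going by these compounds, whether a chlorine atom, a methoxy group or a hydroxyl group on the same aromatic carbon would give a number in this assay stays open, as does any reading of a substituent on another carbon of the anilino ring.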